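Dropping One Fluoro from the Trifluorophenyl Pyrazole Amide

The source may report more compounds than this note shows. Statements on the series, on what has been measured and on what is new or still open speak of the compounds shown alone.

Compound 1, `O=C(NCCO)c1cc(-c2ccc(Cl)c(Cl)c2Cl)n[nH]1`: 5 nM
Compound 2, `O=C(NCCO)c1cc(-c2cc(F)c(F)cc2F)n[nH]1`: 134 nM

In an assay on isolated protein for inhibition of alkaline phosphatase, tissue-nonspecific isozyme (Homo sapiens) (on this read-out higher numbers stand for weaker inhibition and lower numbers for stronger inhibition), compound 2 stands at the highest of the two numbers, with compound 1 a much lower number beyond the scatter. Compound 3, `O=C(NCCO)c1cc(-c2ccc(F)cc2F)n[nH]1`, differs from compound 2 in one place: hydrogen in place of fluoro on an aromatic carbon. Going by the values given here, no measured pair shows this kind of change, so the expected step from compound 2 to compound 3 is small, a 1.5-fold higher number from compound 2 to compound 3 (0.17 log units; within the scatter), toward a slightly higher number and within the scatter. Compound 3 is therefore estimated at 200 nM, with a range from 60 nM to 700 nM.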

Compound 3, half-maximal inhibitory concentration: 35 nM
Compound 3: the middle estimate sits 5.7-fold (0.76 log units) above what was measured; measured number below the stated range.
By their numbers in this assay, from the lowest: compound 1; then compound 3; then compound 2.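

In this assay, putting hydrogen in place of the fluoro on this aromatic carbon, ortho to a fluoro group and para to a fluoro group, gives a 3.8-fold lower number from compound 2 to compound 3 (0.58 log units; beyond the scatter). The fluoro at this position is therefore not needed for inhibition in this series, and its loss improves the number beyond the scatter. Nothing measured here accounts for this gain. Open, from the compounds shown here alone, is how a methyl or methoxy group on this same carbon would compare with hydrogen. Also open, going by these compounds, is whether losing either remaining fluoro would shift the number the same way.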